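Raji cell cytotoxicity of three amides, with a fourth awaiting measurement

A few compounds are considered here, and "the series" means these few. Any claim that something is new, unique, unknown or untested is made for them only; others in the source may bear on it.

Compound 1, `CC(C)N(Cc1cccc(OCCCCCC(=O)O)c1)C(=O)c1ccc(-c2ccoc2)cc1`, in an ADME assay on Raji cells (Homo sapiens) for cytotoxicity, read by CellTiter-Glo and resazurin assay, with a stated time of 72 h (a higher number here means that more compound is needed for the effect, a lower number that less compound is needed), gives only a limit, > 26000 nM.
Compound 2, `CC(C)Oc1cccc(-c2ccc(C(=O)N(Cc3cccc(OCCCCCC(=O)O)c3)C(C)C)cc2)c1`, in this assay likewise gives only a limit, > 26000 nM.
Compound 3, `CCOC(=O)CCCCCOc1cccc(CN(C(=O)c2ccc(-c3ccoc3)cc2)C(C)C)c1`, in this assay also gives only a limit, > 26000 nM.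

All three values sit at the limit of > 26000 nM in this assay, at which 3 of the 3 values shown sit, so neither change between measured compounds can be read. The change 3-isopropoxyphenyl in place of furan-3-yl on an aromatic carbon gives a step that the two limits leave unreadable from compound 1 to compound 2. The change ethyl in place of hydrogen on an oxygen next to a carbonyl group gives a step that the two limits leave unreadable from compound 1 to compound 3; this is also how the core of compound 3 differs from the core of compound 1.

Compound 4, `CCOC(=O)CCCCCOc1cccc(CN(C(=O)c2ccc(-c3cccc(OC(C)C)c3)cc2)C(C)C)c1`, has not yet been measured in this assay. It differs from compound 3 by 3-isopropoxyphenyl in place of furan-3-yl on an aromatic carbon, the same change as that from compound 1 to compound 2, made here on the core of compound 3. Because that earlier change gave a step that the two limits leave unreadable from compound 1 to compound 2, and the core change gave a step that the two limits leave unreadable from compound 1 to compound 3, the step is expected to be a step that the limit leaves unreadable from compound 3 to compound 4, most likely again ending at the limit. Compound 4 is therefore estimated at 45000 nM, expected between 15000 nM and 150000 nM.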

Compound 4, half-maximal effective concentration: > 26000 nM
Compound 4 ended at the assay's limit; the forecaster's own chance of this, stated with the estimate: 80%; the middle value is on the limit's open side.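

In this assay compound 4 gives only a limit, > 26000 nM. No step from compound 2 or compound 3 to compound 4 can therefore be read: the limit of > 26000 nM in this assay, at which 4 of the 4 values shown sit.

The compounds shown leave open what concentration, if any, would give the half-maximal effect for any of the four, and whether either change alters it.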